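Swapping the Bromophenyl Arm for a Chlorofluorophenyl

The source may report more compounds than this note shows. Statements on the series, on what has been measured and on what is new or still open speak of the compounds shown alone.

Compound 1 `O=C(O)CCC(=O)N1N=C(c2c(-c3ccccc3)c3cc(Cl)ccc3[nH]c2=O)CC1c1ccc(Br)cc1` gives 3100 nM in an assay on cells (Oocyte) for negative allosteric modulation of glutamate receptor ionotropic, NMDA 2D (Rattus norvegicus), read by two-electrode voltage clamp; on this read-out higher numbers stand for weaker inhibition and lower numbers for stronger inhibition.
Compound 2 `O=C(O)CCC(=O)N1N=C(c2c(-c3ccc(Br)cc3)c3ccccc3[nH]c2=O)CC1c1ccc(Cl)cc1` gives 290 nM in this assay.
Compound 3 `Cc1cccc(-c2c(C3=NN(C(=O)CCC(=O)O)C(c4ccc(Cl)cc4)C3)c(=O)[nH]c3ccccc23)c1` gives 1900 nM in this assay.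

Compound 2 has the lowest number of the three, so it is the strongest inhibitor shown. Compound 1, which carries a chlorine on the shared core instead, gives 3100 nM in this assay. Going by the values given here, the one measured step on the same position is a 6.6-fold higher number from compound 2 to compound 3 (0.82 log units; beyond the scatter). Compound 4 `O=C(O)CCC(=O)N1N=C(c2c(-c3ccc(F)c(Cl)c3)c3ccccc3[nH]c2=O)CC1c1ccc(Cl)cc1` differs from compound 2 by 3-chloro-4-fluorophenyl in place of 4-bromophenyl on an aromatic carbon. Among the compounds with values here, only the step to compound 3 bears on this change, and that step removed the halogen entirely; compound 4 keeps two halogens on the ring. A small weakening in this assay, near the edge of the scatter, is therefore expected. Compound 4 is estimated at 500 nM, within 150 nM to 1800 nM, which means an expected 1.7-fold higher number from compound 2 to compound 4 (0.24 log units; within the scatter).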

Compound 4, half-maximal inhibitory concentration: 1000 nM
Estimate against measurement, compound 4: 2.0-fold (0.30 log units) below; the range from low to high includes it.
By their numbers in this assay, from the lowest: compound 2; then compounds 4, 3 and 1 (each within the scatter of the next, the first and the last beyond it).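

The step of a 3.4-fold higher number from compound 2 to compound 4 (0.54 log units; beyond the scatter) shows that two halogens on this ring do not by themselves keep the inhibition seen with 4-bromophenyl. In this assay the step of a 1.9-fold lower number from compound 3 to compound 4 (0.28 log units; within the scatter) lies within the scatter, so the 3-chloro-4-fluorophenyl and 3-methylphenyl arms cannot be told apart here. No measurement at hand explains why 4-bromophenyl gives the lower number.

Still open, from the compounds shown here alone, is how a 4-chlorophenyl or 4-methoxyphenyl arm on this same aromatic carbon would compare with 4-bromophenyl. Also open, going by these compounds, is what an amine on this ring would do.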